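A few compounds are considered here, and "the series" means these few. Any claim that something is new, unique, unknown or untested is made for them only; others in the source may bear on it.

In a functional assay on MGC-803 cells (Homo sapiens) for cytotoxicity, read by MTT assay, with a stated time of 72 h (on this read-out lower numbers stand for stronger inhibition and higher numbers for weaker inhibition), compound 1 `COc1cc2ncnc(NNC(=S)NC(=O)c3ccccc3Cl)c2cc1OC` gives 6440 nM, compound 3 `O=C(NC(=S)NNc1ncnc2ccccc12)c1ccccc1Cl` gives 9140 nM, and compound 2 `COc1cc2ncnc(NNC(=S)NC(=O)c3ccc(C)cc3)c2cc1OC` gives 19700 nM. Compound 2 therefore stands at the highest number of the three, and since both of its gaps to the other compounds lie beyond the scatter, it is the weakest inhibitor of this small set. Compound 1 and compound 2 differ only in the ring attached to the carbonyl carbon, and that single swap produced a 3.1-fold higher number from compound 1 to compound 2 (0.49 log units; beyond the scatter).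

Compound 4 `COc1cc2ncnc(NNC(=S)NC(=O)c3ccccc3C)c2cc1OC` has not been measured yet. It differs from compound 2 by 2-methylphenyl in place of 4-methylphenyl on a carbonyl carbon, so the same atoms are kept and only the place of the methyl group on the ring moves. For the measured compounds named here, the one measured step that touches this position is the move from compound 1 to compound 2, where a 2-substituted ring gave the lower number and a 4-methylphenyl gave the higher one; compound 4 partly turns that move back, though it keeps methyl rather than chloro, so the step carries over only loosely. A modest drop in the number is expected, a 2.1-fold lower number from compound 2 to compound 4 (0.32 log units; beyond the scatter). Compound 4 is estimated at 9500 nM, with a range from 4500 nM to 20000 nM.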

Compound 4, half-maximal inhibitory concentration: 11100 nM
Compound 4: the middle estimate sits 1.2-fold (0.07 log units) below what was measured; the range from low to high includes it.
By their numbers in this assay, from the lowest: compounds 1, 3, 4 and 2 (each within the scatter of the next, the first and the last beyond it).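

In this assay moving the methyl group from 4-methylphenyl to 2-methylphenyl on the carbonyl carbon gives a 1.8-fold lower number from compound 2 to compound 4 (0.25 log units; within the scatter) and so shows that, for this pair, the place of the methyl group on the ring cannot be told apart from the usual scatter. Methyl in place of chloro on the aromatic carbon gives a 1.7-fold higher number from compound 1 to compound 4 (0.24 log units; within the scatter) and so shows that these two groups cannot be separated here either, which means that the clear gap between compound 1 and compound 2 appears only when the group and its place on the ring differ together, while each change alone stays within the scatter. No measurement shown here accounts for these small steps.

The compounds shown leave open how this ring would respond to quite different groups, such as a methoxy group, an amine or a carboxylic acid, in place of the methyl or chloro. They also leave open whether 2-methylphenyl and 4-methylphenyl would stay this close on the core of compound 3, which lacks the two methoxy groups of compound 1.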